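Compound 3 to compound 4: nitro in place of bromo

The source may report more compounds than this note shows. Statements on the series, on what has been measured and on what is new or still open speak of the compounds shown alone.

In a functional assay on MCF7 cells (Homo sapiens) for cytotoxicity, read by MTT assay, with a stated time of 96 h (a lower number here means a stronger inhibitor, a higher number a weaker inhibitor), compound 3 (`COc1cc(C(=O)c2cn(-c3cccc(Br)c3)cc2-c2ccccc2)cc(OC)c1OC`) gives 78 nM as the lowest of three numbers. Compound 1 (`COc1cc(C(=O)c2cn(-c3ccccc3C)cc2-c2ccccc2)cc(OC)c1OC`) gives 2200 nM and compound 2 (`COc1cc(C(=O)c2cn(-c3ccccc3N)cc2-c2ccccc2)cc(OC)c1OC`) gives 3800 nM as the other two.

Compound 4 (`COc1cc(C(=O)c2cn(-c3cccc([N+](=O)[O-])c3)cc2-c2ccccc2)cc(OC)c1OC`) is still unmeasured and carries nitro in place of bromo on an aromatic carbon. Within the data shown here, no measured step makes this exact change. The large steps, a 28-fold lower number from compound 1 to compound 3 (1.45 log units; beyond the scatter) and a 49-fold lower number from compound 2 to compound 3 (1.69 log units; beyond the scatter), each replace a whole substituted phenyl group and do not isolate the bromo.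

Among the measured compounds shown here, the closest precedent is the replacement of one group on an aromatic carbon, a 1.7-fold higher number from compound 1 to compound 2 (0.24 log units; within the scatter), and that step stays within the scatter. On that basis, no step beyond the scatter is expected in this assay, and the direction remains uncertain. The estimate of a 1.5-fold higher number from compound 3 to compound 4 (0.19 log units; within the scatter) is therefore a small expected step. Compound 4 is estimated at 120 nM with a range from 35 nM to 450 nM as the expected span.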

Compound 4, half-maximal inhibitory concentration: 550 nM
For compound 4 the middle estimate is 4.6-fold (0.66 log units) below the measured one; the whole stated range lies below it.
By their numbers in this assay, from the lowest: compound 3; then compound 4; then compounds 1 and 2 (each within the scatter of the next).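

In this assay the swap of bromo for nitro gives a 7.1-fold higher number from compound 3 to compound 4 (0.85 log units; beyond the scatter) as a change of one group on this aromatic carbon, so the identity of that group moves the number beyond the scatter, and the earlier large steps, which replaced a whole substituted phenyl, could not show this. With 3-nitrophenyl on the aromatic nitrogen the series still records a 6.9-fold lower number from compound 2 to compound 4 (0.84 log units; beyond the scatter) and a 4.0-fold lower number from compound 1 to compound 4 (0.60 log units; beyond the scatter) as steps, so this compound keeps part of the advantage over the 2-methylphenyl and 2-aminophenyl compounds, though less than 3-bromophenyl does. Nothing available here accounts for the difference between bromo and nitro.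

Open, on these data alone, is whether chloro or methoxy on the same aromatic carbon would fall nearer to bromo or to nitro. Also open, as far as these compounds go, is how much of the distance from compound 1 and compound 2 comes from the place of the group, as those steps change group and place together.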